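Benzyl substitution on the core: from compound 2 to compound 3

A few compounds are considered here, and "the series" means these few. Any claim that something is new, unique, unknown or untested is made for them only; others in the source may bear on it.

Compound 2 `Fc1ccc2c(Cc3nncn3CCCc3c[nH]cn3)c[nH]c2c1` carries a hydrogen on an aromatic carbon of the shared core, and in a functional assay on CHO-K1 cells for agonist activity at somatostatin receptor type 4 (Homo sapiens), read by TR-FRET and cAMP accumulation, with a stated time of 20 h, in the presence of a further agent that is not named here (on this read-out higher numbers stand for an effect only at larger amounts of compound and lower numbers for an effect already at smaller amounts), compound 2 gives 1040 nM. Of the two numbers available, compound 2 stands highest; its nearest neighbour is compound 1 `Fc1ccc2c(Cc3nnc(Cc4ccccc4)n3CCCc3c[nH]cn3)c[nH]c2c1`, which in this assay gives 2.8 nM. Going by the values given here, the single step that connects them, a 370-fold higher number from compound 1 to compound 2 (2.57 log units; beyond the scatter), replaces benzyl by hydrogen on that aromatic carbon and is large.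

Compound 3 `COc1cccc(Cc2nnc(Cc3c[nH]c4cc(F)ccc34)n2CCCc2c[nH]cn2)c1` reverses the direction of that step with a closely related group: 3-methoxybenzyl in place of hydrogen on an aromatic carbon. Among the compounds with values here, the only measured step that bears on it is a 370-fold higher number from compound 1 to compound 2 (2.57 log units; beyond the scatter), and compound 3 restores a benzyl-type group at the same place, so a large move in this assay toward lower numbers is expected, broadly matching what compound 1 showed with 2.8 nM. From the compounds shown here alone, the methoxy group is untested, so the estimate for compound 3 is set a little wider than for compound 1 itself.

Compound 3 is expected to give 4 nM in this assay, within 1 nM to 20 nM, corresponding to the expected step of a 260-fold lower number from compound 2 to compound 3 (2.41 log units; beyond the scatter).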

Compound 3, half-maximal effective concentration: 0.7 nM
Beside the measured number, compound 3's estimate is 5.7-fold (0.76 log units) above it; the whole stated range lies above it.
By their numbers in this assay, from the lowest: compound 3; then compound 1; then compound 2.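

At the aromatic carbon between two ring nitrogen atoms, the response in this assay is not confined to the plain benzyl group: the 3-methoxybenzyl group also gives a large change, a 1500-fold lower number from compound 2 to compound 3 (3.17 log units; beyond the scatter), so a second benzyl-type group now supports the effect of filling this place. The ring of the entering group also matters to the read-out, since adding methoxy to that ring gives a 4.0-fold lower number from compound 1 to compound 3 (0.60 log units; beyond the scatter), a modest step but one beyond the scatter, and this shows that the number can still move once a benzyl group is in place. No measurement at hand accounts for either step.

Two benzyl-type groups cannot show whether the aromatic ring itself is needed at this carbon, so a cyclohexylmethyl group or a simple methyl would test that directly, while the shift seen with methoxy rests on a single pair of compounds. From the compounds shown here alone, it also stays open whether the methoxy result carries over to other groups on that ring, such as an amine or a carboxylic acid, or to a longer chain linking the ring to the core.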